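The source may report more compounds than this note shows. Statements on the series, on what has been measured and on what is new or still open speak of the compounds shown alone.

Compound 2 `Cc1ccc(C(=O)N2N=C(c3ccccc3)CC2c2cn(C)c3ccccc23)cn1` and compound 1 `COc1ccc(C(=O)N2N=C(c3ccccc3)CC2c2cn(C)c3ccccc23)cn1` share one core; in a functional assay on A549 cells (Homo sapiens) for inhibition, read by MTT assay, with a stated time of 48 h (on this read-out higher numbers stand for weaker inhibition of growth and lower numbers for stronger inhibition of growth), compound 2 gives 1190 nM and compound 1 gives 3040 nM. Within the data shown here, the single change between them, (methoxy in place of methyl on an aromatic carbon), produced a 2.6-fold higher number from compound 2 to compound 1 (0.41 log units; beyond the scatter). Compound 3 `COc1cccc(C2=NN(C(=O)c3ccc(C)nc3)C(c3cn(C)c4ccc(OC)cc34)C2)c1` stands on a second core; in this assay compound 3 gives 590 nM. How the two cores differ is not broken down here. Compound 4 `COc1cccc(C2=NN(C(=O)c3ccc(OC)nc3)C(c3cn(C)c4ccc(OC)cc34)C2)c1` is not yet measured and carries the same change relative to compound 3, (methoxy in place of methyl on an aromatic carbon), at the same place on the same ring. Because the earlier step read a 2.6-fold higher number from compound 2 to compound 1 (0.41 log units; beyond the scatter), a step of similar size and direction is expected for compound 4, namely a 2.5-fold higher number from compound 3 to compound 4 (0.41 log units; beyond the scatter); this rests on one pair only, so it is a loose expectation. In this assay compound 4 is expected at 1500 nM, between 700 nM and 3200 nM.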

Compound 4, concentration for 50% growth inhibition: 470 nM
Compound 4: the middle estimate sits 3.2-fold (0.50 log units) above what was measured; measured number outside the range, below it.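

Replacing methyl with methoxy, 6-methylpyridin-3-yl to 6-methoxypyridin-3-yl, gave a 1.3-fold lower number from compound 3 to compound 4 (0.10 log units; within the scatter) in this assay, so this change does not carry from one core to the other as a fixed step: the same change on two cores in this assay, a 2.6-fold higher number (0.41 log units; beyond the scatter) from compound 2 to compound 1 and a 1.3-fold lower number (0.10 log units; within the scatter) from compound 3 to compound 4, 3.2-fold (0.51 log units) apart, beyond the scatter of two such steps

Within these two pairs, the outcome of the change therefore depends on the core that carries it. This does not show which difference between the cores accounts for the gap, and one pair per core gives no general rule for the series.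

Still open, from the compounds shown here alone, is how an amine or an ethoxy group at the same place would read on each core. Also open, going by these compounds, is how the methoxy-for-methyl step would read on a core intermediate between the two.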